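Allyloxy replacing the arylsulfanyl group: working notes

The compounds below may be only part of what the source reports. "The series", "measured", "known", "first", "only" and "open" are said of these compounds alone.

Measured in a functional assay on MCF7 cells (Homo sapiens) for antiproliferative activity, read by sulforhodamine B assay, with a stated time of 3 days; a lower number here means a stronger inhibitor, a higher number a weaker inhibitor:
- compound 1 `c1ccc2c(c1)COC(n1cnc3ncnc(OCC4CCCCC4)c31)CO2`: 13400 nM
- compound 2 `c1ccc(Oc2ncnc3ncn(C4COc5ccccc5CO4)c23)cc1`: 21100 nM
- compound 3 `Clc1ccc(Sc2ncnc3ncn(C4COc5ccccc5CO4)c23)c(Cl)c1`: 8400 nM

Not yet measured: compound 4 `C=CCOc1ncnc2ncn(C3COc4ccccc4CO3)c12`.

Compound 3, at 8400 nM, stands clear of the scatter only against compound 2: a 2.5-fold lower number from compound 2 to compound 3 (0.40 log units; beyond the scatter). Against compound 1 the gap is small: a 1.6-fold lower number from compound 1 to compound 3 (0.20 log units; within the scatter).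

Compound 4 carries allyloxy in place of (2,4-dichlorophenyl)sulfanyl on an aromatic carbon. Within the data shown here, no measured compound carries allyloxy, so the evidence is indirect. The closest guide is compound 2, where phenoxy gives way to the same sulfanyl group: a 2.5-fold lower number from compound 2 to compound 3 (0.40 log units; beyond the scatter). Compound 1 offers a weaker guide, since its exchange of cyclohexylmethoxy for that group gives a 1.6-fold lower number from compound 1 to compound 3 (0.20 log units; within the scatter). The two ether groups themselves differ little: a 1.6-fold higher number from compound 1 to compound 2 (0.20 log units; within the scatter).

A modest step towards a higher number is therefore expected in this assay, estimated as a 2.4-fold higher number from compound 3 to compound 4 (0.38 log units; beyond the scatter). For compound 4 the estimated value is 20000 nM, with an expected range of 9000 nM to 45000 nM.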

Compound 4, half-maximal inhibitory concentration: 20900 nM
Estimate against measurement, compound 4: 1.0-fold (0.02 log units) below; the measured number falls inside the stated range.
By their numbers in this assay, from the lowest: compounds 3, 1, 4 and 2 (each within the scatter of the next, the first and the last beyond it).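

In this assay, allyloxy on this aromatic carbon does not keep the lower number seen with (2,4-dichlorophenyl)sulfanyl (a 2.5-fold higher number from compound 3 to compound 4 (0.40 log units; beyond the scatter)), yet it matches the phenoxy group (a 1.0-fold lower number from compound 2 to compound 4 (0.00 log units; within the scatter)) and the cyclohexylmethoxy group (a 1.6-fold higher number from compound 1 to compound 4 (0.19 log units; within the scatter)). Allyl, phenyl and cyclohexylmethyl on the oxygen therefore all lie within the scatter of one another, so a short chain with a double bond and no ring reads the same as both ring-bearing groups, while compound 3 stands beyond the scatter from compound 2 and compound 4 but not from compound 1. No measured evidence accounts for these steps.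

The compounds shown do not separate the effect of the sulfur link from that of the two chlorines in compound 3. From the compounds shown here alone, how an amine or a carboxylic acid on this carbon would read remains open.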